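From aminopropyl to bromobutyl on a shared core

A few compounds are considered here, and "the series" means these few. Any claim that something is new, unique, unknown or untested is made for them only; others in the source may bear on it.

The values in an ADME assay on MDCK cells (Canis lupus familiaris) for cytotoxicity, read by MTT assay, with a stated time of 2 days (on this read-out higher numbers stand for lower toxicity in this test and lower numbers for higher toxicity in this test), are these
- compound 1 `NCCCc1ccc(-c2ccc(-c3cccs3)s2)s1` gives 18900 nM as a number
- compound 2 `NCCCc1ccc(-c2ccc(-c3ccc(CCCN)s3)s2)s1` gives > 200000 nM as a limit
- compound 3 `BrCCCc1ccc(-c2ccc(-c3ccc(-c4cccs4)s3)s2)s1` gives > 200000 nM as a limit
- compound 4 `BrCCCCc1ccc(-c2ccc(-c3cccs3)s2)s1` has not yet been measured

Compound 1 holds the only true number among those shown. The other data stop at the limit of > 200000 nM in this assay, at which 2 of the 3 values shown sit, and give no number.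

Compound 4 alters the chain end of compound 1 (bromomethyl in place of amino on a saturated chain carbon, three bonds along the chain from an aromatic carbon). Bromomethyl stands in place of amino on a saturated chain carbon, three bonds along the chain from an aromatic carbon, so that 3-aminopropyl becomes 4-bromobutyl.

For the measured compounds named here, the one measured step is large (an at least 10-fold higher number from compound 1 to compound 2 (1.02 log units; beyond the scatter)), but it adds a 3-aminopropyl chain rather than replacing the amino group, so it bears on this change only indirectly. Compound 3 has no amino group and carries 3-bromopropyl on a different core, and its limit of > 200000 nM supports the expectation of a higher number.

Going by the values given here, a large step to a higher number is therefore expected in this assay (a 4.8-fold higher number from compound 1 to compound 4 (0.68 log units; beyond the scatter)), though no measured pair tests this exact change. Compound 4 is estimated at 90000 nM within an expected range from 25000 nM to 300000 nM and may return only a limit.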

Compound 4, half-maximal cytotoxic concentration: 23800 nM
The estimate for compound 4 lay 3.8-fold (0.58 log units) above the measured number; measured number below the stated range.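

In this assay, replacing the amino end of the chain with bromomethyl, so that 3-aminopropyl becomes 4-bromobutyl, gives a 1.3-fold higher number from compound 1 to compound 4 (0.10 log units; within the scatter), and on this core the two chain ends cannot be told apart in this test. For the compounds shown here, the only earlier step, an at least 10-fold higher number from compound 1 to compound 2 (1.02 log units; beyond the scatter), added a second 3-aminopropyl chain and left the amino group of the first in place, whereas this result shows that the number of compound 1 does not depend on that amino group, since the entering bromomethyl has no hydrogen-bond donor or acceptor. Compound 2 and compound 3 stay limits rather than numbers, so neither can be set against this result: the limit of > 200000 nM in this assay, at which 2 of the 4 values shown sit.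

Because the change alters the chain end and the chain length together, the compounds shown do not separate the two, and 4-aminobutyl or 3-bromopropyl on the core of compound 1 would be needed to do so. They also leave open whether a hydroxyl or a carboxylic acid at the end of this chain would give a number in the same range, or whether a longer chain would.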